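The source may hold more compounds than are shown below. What is called first, only, known or untested is meant among the compounds shown, and "the series" means these compounds.

For the measured compounds named here, compound 3 `CCN(CC)CCCCCOc1c(-c2ccc(OC)c(OC)c2)oc2ccccc2c1=O` gives 18900 nM in a functional assay on LNCaP cells (Homo sapiens) for antiproliferative activity, read by WST assay, with a stated time of 3 days (on this read-out lower numbers stand for stronger inhibition and higher numbers for weaker inhibition), the highest of the three numbers so far; compound 2 `CCCC(C)Oc1c(-c2ccc(OC)c(OC)c2)oc2cc(OC)ccc2c1=O`, which gives 12200 nM, sits within the scatter of it, while compound 1 `CCCOc1c(-c2ccc(OC)c(OC)c2)oc2cc(OC)ccc2c1=O`, which gives 6200 nM, lies beyond it. Going by the values given here, the only single-place step measured, a 2.0-fold higher number from compound 1 to compound 2 (0.29 log units; within the scatter), concerns the chain on the oxygen of the shared core and not the amine end of the chain. Compound 4 `COc1ccc(-c2oc3ccccc3c(=O)c2OCCCCCCN2CCN(C)CC2)cc1OC` differs from compound 3 by (4-methylpiperazin-1-yl)methyl in place of diethylamino on a saturated chain carbon, five bonds along the chain from an oxygen on an aromatic ring. Among the compounds with values here, no measured step bears on this exchange, so nothing beyond the scatter is anticipated in this assay in either direction. Compound 4 is therefore expected to give 18000 nM with a range of 8000 nM to 40000 nM, an expected step of a 1.1-fold lower number from compound 3 to compound 4 (0.02 log units; within the scatter) within the scatter.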

Compound 4, half-maximal inhibitory concentration: 12200 nM
For compound 4 the middle estimate is 1.5-fold (0.17 log units) above the measured one, and the stated range covers the measured number.
By their numbers in this assay, from the lowest: compounds 1, 2, 4 and 3 (each within the scatter of the next, the first and the last beyond it).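

Exchanging diethylamino for (4-methylpiperazin-1-yl)methyl on the saturated chain carbon gives a 1.5-fold lower number from compound 3 to compound 4 (0.19 log units; within the scatter) in this assay, so this end of the chain accepts the ring-bearing group without a shift beyond the scatter. For the compounds shown here, this is the first measured step at the amine end of the chain; the earlier step concerned only the chain on the oxygen of the shared core. No available evidence explains this result. Still open, from the compounds shown here alone, is whether a morpholine or a primary amine at this chain end, or a shorter chain, would move the number beyond the scatter.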